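Swapping an aryl group for a furan at the limit

The compounds below may be only part of what the source reports. "The series", "measured", "known", "first", "only" and "open" are said of these compounds alone.

Compound 1 `CC(=O)c1cccc(-c2ccc(C(=O)N(Cc3cccc(OCCCCCC(=O)O)c3)C(C)C)cc2)c1`: > 26000 nM (a limit)
Compound 2 `CC(C)N(Cc1cccc(OCCCCCC(=O)O)c1)C(=O)c1ccc(-c2cccc(O)c2)cc1`: > 26000 nM (a limit)
Compound 3 `CCOC(=O)CCCCCOc1cccc(CN(C(=O)c2ccc(-c3cccc(NC(C)=O)c3)cc2)C(C)C)c1`: > 26000 nM (a limit)

These results come from an ADME assay on HepG2 cells (Homo sapiens) for cytotoxicity, read by CellTiter-Glo and resazurin assay, with a stated time of 72 h (on this read-out higher numbers stand for an effect only at larger amounts of compound and lower numbers for an effect already at smaller amounts), and none of them is an exact number: the limit of > 26000 nM in this assay, at which 3 of the 3 values shown sit. Compound 3 stands at > 26000 nM, which is a limit.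

Compound 4 `CCOC(=O)CCCCCOc1cccc(CN(C(=O)c2ccc(-c3ccoc3)cc2)C(C)C)c1` differs from compound 3 in one place: furan-3-yl in place of 3-acetamidophenyl on an aromatic carbon. The closest measured change also replaces a group on an aromatic carbon, but it gives no size: a step that the two limits leave unreadable from compound 1 to compound 2. Among the compounds with values here, with only that step as a guide, no change beyond the usual scatter is expected, in either direction. The expected change is a number no higher from compound 3 to compound 4 (the limit leaves the size open). For compound 4 the estimate is 26000 nM, with an expected range of 13000 nM to 52000 nM.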

Compound 4, half-maximal effective concentration: > 26000 nM
Compound 4: no number, only a limit; the forecaster's own chance of this, stated with the estimate: 80%; the middle value lies on the limit itself.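

No size can be read for the change from compound 3 to compound 4, because both results are limits: the limit of > 26000 nM in this assay, at which 4 of the 4 values shown sit.

The compounds shown leave open what effect, if any, furan-3-yl in place of 3-acetamidophenyl has in this assay.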